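Sulfamoyl in place of methoxy: notes on the series

The source may hold more compounds than are shown below. What is called first, only, known or untested is meant among the compounds shown, and "the series" means these compounds.

Values in a functional assay on RKO cells (Homo sapiens) for cytotoxicity, read by resazurin assay, with a stated time of 72 h; on this read-out higher numbers stand for weaker inhibition and lower numbers for stronger inhibition:
compound 1 `COc1cccc(Nc2nc(-n3cc(C)nc3C)cs2)c1`: 22500 nM
compound 2 `COc1ccc(Nc2nc(-n3ccnc3C)cs2)cc1`: 1600 nM

Compound 2 holds the lower of the two numbers, and its gap to compound 1 lies beyond the scatter. Compound 3 `Cc1nccn1-c1csc(Nc2ccc(S(N)(=O)=O)cc2)n1`, still unmeasured, differs from compound 2 by sulfamoyl in place of methoxy on an aromatic carbon, para to a large group (sulfamoyl in place of methoxy on an aromatic carbon). Among the compounds with values here, no two measured compounds differ in one place only, so the data offer no direct guide to this change. Within the data shown here, with compound 2 at 1600 nM, the lower of only two values, a move to a higher number seems more likely than a further fall. In this assay the expected change is a 5.0-fold higher number from compound 2 to compound 3 (0.70 log units; beyond the scatter), a moderate weakening probably beyond the scatter. For compound 3 the estimated value is 8000 nM, with an expected range of 2000 nM to 30000 nM.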

Compound 3, half-maximal inhibitory concentration: 49000 nM
The estimate for compound 3 lay 6.1-fold (0.79 log units) below the measured number; the whole stated range lies below it.
By their numbers in this assay, from the lowest: compound 2; then compound 1; then compound 3.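

In this assay, sulfamoyl in place of methoxy on an aromatic carbon, para to a large group, brings a 31-fold higher number from compound 2 to compound 3 (1.49 log units; beyond the scatter) as the first single-place change readable in the series, and a large one. This position is therefore not indifferent to the group it carries: with the rest of the structure unchanged, the number moves well beyond the scatter, and methoxy holds the lower value of the pair. Nothing measured bears on the reason for this step.

Open, from the compounds shown here alone, is whether the rise belongs to sulfamoyl in particular or would also come with other groups on the same aromatic carbon, such as an amine, a carboxylic acid or a methylsulfonyl group. Also open, going by these compounds, is whether the same exchange on compound 1 would bring a step of similar size.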